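The source may hold more compounds than are shown below. What is called first, only, known or untested is meant among the compounds shown, and "the series" means these compounds.

Measured compounds:
compound 1 `CCCCCCCOc1ccc(CCC(N)(CO)C(C)C)cc1` — 2.7 mg/kg
compound 2 `CCCCCCCOc1ccc(CCC(N)(CO)CCC)cc1` — 3.1 mg/kg

In a functional assay on the whole organism (spleen, spleen) with Rattus norvegicus as the target (a higher number here means that more compound is needed for the effect, a lower number that less compound is needed), compound 2 gives 3.1 mg/kg, the higher of the two numbers; compound 1 gives 2.7 mg/kg. For the measured compounds named here, the only step known, a 1.1-fold higher number from compound 1 to compound 2 (0.06 log units; within the scatter), concerns a chain swap and says nothing about configuration. Compound 3 `CCCCCCCOc1ccc(CC[C@@](N)(CO)CCC)cc1` differs from compound 2 thus: the two compounds have the same atoms and bonds; at least one stereo element is drawn with a configuration in one of them and without one in the other: 1 of 1 stereo elements differ; a stereocentre at a saturated chain carbon is drawn without a configuration in compound 2 and R in compound 3. Going by the values given here, no measured step bears on resolving a stereocentre here, so the direction is open; a single enantiomer may need less compound than the mixture or more. Compound 3 is therefore expected near compound 2, with a broad range: 2.5 mg/kg, from 1 mg/kg to 8 mg/kg, a step of a 1.2-fold lower number from compound 2 to compound 3 (0.09 log units; within the scatter).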

Compound 3, dose for 50% inhibition: 0.63 mg/kg
Beside the measured number, compound 3's estimate is 4.0-fold (0.60 log units) above it; the whole stated range lies above it.
By their numbers in this assay, from the lowest: compound 3; then compounds 1 and 2 (each within the scatter of the next).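

In this assay the chain swap had stayed within the scatter, but the stereocentre at this saturated chain carbon matters, with a 4.9-fold lower number from compound 2 to compound 3 (0.69 log units; beyond the scatter) on drawing it as R. The same direction appears with a 4.3-fold lower number from compound 1 to compound 3 (0.63 log units; beyond the scatter) in a step that changes chain and configuration together. The first of these steps belongs to the stereocentre alone, because nothing else differs: the fact that one of compounds 2 and 3 is drawn with a defined configuration and the other without, at the place where they differ.

Open, going by these compounds, is how the S form compares with the R form. Also open, on these data alone, is whether a longer chain at this carbon keeps the low dose.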